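A Second Variation on Compound 1

The compounds below may be only part of what the source reports. "The series", "measured", "known", "first", "only" and "open" are said of these compounds alone.

Compound 1 `COc1cc(CSc2cc(Cl)c(-c3nnc(-c4ccc(Cl)cc4)s3)cc2S(=O)(=O)NC(=N)NO)cc(OC)c1OC` was examined in a functional assay on IGROV-1 cells (Homo sapiens) (a higher number here means a weaker inhibitor of growth, a lower number a stronger inhibitor of growth), where compound 1 gives 58900 nM. This is the highest of the two numbers at hand. Among the compounds with values here, compound 2 `N=C(NO)NS(=O)(=O)c1cc(-c2nnc(-c3ccc(Cl)cc3)s2)c(Cl)cc1SCc1ccccc1` differs from compound 1 only by phenyl in place of 3,4,5-trimethoxyphenyl on a saturated chain carbon bound to a sulfur, and in this assay compound 2 gives 2570 nM; the step of a 23-fold lower number from compound 1 to compound 2 (1.36 log units; beyond the scatter) is the only measured step in this set. Compound 3 `COc1cc(CSc2cc(Cl)c(-c3nc(-c4ccccc4)no3)cc2S(=O)(=O)NC(=N)NO)cc(OC)c1OC` is not yet measured. It differs from compound 1 at another place: 3-phenyl-1,2,4-oxadiazol-5-yl in place of 5-(4-chlorophenyl)-1,3,4-thiadiazol-2-yl on an aromatic carbon. Within the data shown here, the measured step from compound 1 to compound 2 concerns a different part of the molecule and so says nothing directly about this exchange; no measured pair in this set varies the group at this position. Among the measured compounds shown here, with no step to lean on, the expectation for compound 3 rests on compound 1 alone, and the change is expected to give a 1.2-fold lower number from compound 1 to compound 3 (0.07 log units; within the scatter), that is, no movement beyond the scatter. Compound 3 is therefore estimated at 50000 nM, with a range from 10000 nM to 150000 nM wide enough to allow either direction.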

Compound 3, concentration for 50% growth inhibition: 5620 nM
Compound 3: the middle estimate sits 8.9-fold (0.95 log units) above what was measured; measured number below the stated range.
By their numbers in this assay, from the lowest: compound 2; then compound 3; then compound 1.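

In this assay, the exchange of 5-(4-chlorophenyl)-1,3,4-thiadiazol-2-yl for 3-phenyl-1,2,4-oxadiazol-5-yl gives a 10-fold lower number from compound 1 to compound 3 (1.02 log units; beyond the scatter), which shows that the group on this aromatic carbon, ortho to a chloro group and para to a large group, can move the number well beyond the scatter even with the 3,4,5-trimethoxyphenyl group kept in place. Within the data shown here, the change is not a single one, since the five-membered aromatic ring differs in its atoms, the chlorine on the six-membered aromatic ring is lost, and the single step cannot separate these differences. The data in hand offer no explanation for the step.

Going by these compounds, it remains open whether the five-membered aromatic ring or the loss of the chlorine accounts for the step, a question that a 3-(4-chlorophenyl)-1,2,4-oxadiazol-5-yl group at this position would address. On these data alone, it is also open whether the same exchange would lower the number with phenyl in place of the 3,4,5-trimethoxyphenyl group, and how a smaller group here, such as a methyl group or an amine, would fare.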